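Thiocarbamate-linked benzamides: a saturated ring in place of pyridinyl

The source may hold more compounds than are shown below. What is called first, only, known or untested is meant among the compounds shown, and "the series" means these compounds.

Compound 1, `Nc1ccccc1NC(=O)c1ccc(CSC(=S)N2CCN(C(c3ccccc3)c3ccccc3)CC2)cc1`, gives 8% in a functional assay on HeLa cells (Homo sapiens) for antiproliferative activity, read by CCK-8 assay, with a stated time of 72 h, tested at 2 uM; a higher number here means a stronger effect of the compound at the concentration tested, a lower number a weaker effect.
Compound 2, `CN(C(=S)SCc1ccc(C(=O)Nc2ccccc2N)cc1)c1cccnc1`, gives 16% in this assay.
Compound 3, `COc1ccc(N2CCN(C(=S)SCc3ccc(C(=O)Nc4ccccc4N)cc3)CC2)cc1`, gives 39.4% in this assay.

Among these three, compound 2 holds the second highest number: its value and that of compound 1 lie within the scatter of each other, whereas compound 3 stands beyond the scatter above it. Compound 4, `CC1CCCCN1C(=S)SCc1ccc(C(=O)Nc2ccccc2N)cc1`, has not yet been measured. It differs from compound 2 in one place: 2-methylpiperidin-1-yl in place of methyl(pyridin-3-yl)amino on a thiocarbonyl carbon. Among the compounds with values here, no measured pair shows a step of this kind, so no measured step guides the expectation. Compound 4 is expected to sit near compound 2, with the step from compound 2 to compound 4 estimated at a number 1 percentage points lower from compound 2 to compound 4 (within the scatter), which is not beyond the scatter. For compound 4 the estimate in this assay is 15%, within a range from 3% to 35%.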

Compound 4, a percentage reported as inhibition, at one concentration (the size of the read-out at that concentration, not a potency): 45.5%
For compound 4 the middle estimate is 30.5 percentage points below the measured one; measured number above the stated range.
By their numbers in this assay, from the lowest: compounds 1 and 2 (each within the scatter of the next); then compounds 3 and 4 (each within the scatter of the next).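

In this assay, within the data shown here, the change to 2-methylpiperidin-1-yl on a thiocarbonyl carbon gives a number 29.5 percentage points higher from compound 2 to compound 4 (beyond the scatter) and is the first step measured at this place. It shows that the group here can shift the read-out at the concentration tested, and that a pyridine ring is not required for the higher number. Nothing measured explains the step.

The change replaces the aromatic ring and the open-chain methyl together, so their shares cannot be separated. As far as these compounds go, whether plain piperidin-1-yl or morpholin-4-yl would match 2-methylpiperidin-1-yl remains open.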